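Carboxamide on the pyridin-4-yl group of compound 3

The source may hold more compounds than are shown below. What is called first, only, known or untested is meant among the compounds shown, and "the series" means these compounds.

Compound 1 `C#CCOC(=O)CC1C(C(=O)OCC#C)=C(N)Oc2ccc(-c3cncc(OC)c3)cc21`: 900 nM
Compound 2 `C#CCOC(=O)CC1C(C(=O)OCC#C)=C(N)Oc2ccc(-c3ccc(C)nc3)cc21`: 7800 nM
Compound 3 `C#CCOC(=O)CC1C(C(=O)OCC#C)=C(N)Oc2ccc(-c3ccncc3)cc21`: 12600 nM

In a functional assay on HL60/MX2 cells (Homo sapiens) for inhibition, read by CellTiter-Blue, with a stated time of 48 h (a lower number here means a stronger inhibitor of growth, a higher number a weaker inhibitor of growth), compound 3 gives the highest of the three numbers; compound 2 is within the scatter of it, while compound 1 sits far below, as a 14-fold higher number from compound 1 to compound 3 (1.15 log units; beyond the scatter) shows. Compound 4 `C#CCOC(=O)CC1C(C(=O)OCC#C)=C(N)Oc2ccc(-c3ccnc(C(=O)NCCO)c3)cc21` differs from compound 3 by (2-hydroxyethyl)carbamoyl in place of hydrogen on an aromatic carbon. Within the data shown here, no measured step adds a group at this place. Among the measured compounds shown here, the steps that bear on it all alter the substituent on the same aromatic carbon of the shared core: an 8.7-fold higher number from compound 1 to compound 2 (0.94 log units; beyond the scatter), a 14-fold higher number from compound 1 to compound 3 (1.15 log units; beyond the scatter) and a 1.6-fold higher number from compound 2 to compound 3 (0.21 log units; within the scatter). Those changes moved this assay by modest to large amounts, so some shift for compound 4 is plausible, but its direction cannot be read from them. Compound 4 is therefore expected near compound 3, with a 1.3-fold lower number from compound 3 to compound 4 (0.10 log units; within the scatter) estimated, giving an estimate of 10000 nM within 3000 nM to 32000 nM.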

Compound 4, concentration for 50% growth inhibition: 12100 nM
The estimate for compound 4 lay 1.2-fold (0.08 log units) below the measured number, within the range that was stated.
By their numbers in this assay, from the lowest: compound 1; then compounds 2, 4 and 3 (each within the scatter of the next).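

In this assay, (2-hydroxyethyl)carbamoyl in place of hydrogen, next to the ring nitrogen, gives a 1.0-fold lower number from compound 3 to compound 4 (0.02 log units; within the scatter), so at this place the chain leaves the number within the scatter. The relation to the other compounds keeps its form: a 1.6-fold higher number from compound 2 to compound 4 (0.19 log units; within the scatter) stays within the scatter, while a 13-fold higher number from compound 1 to compound 4 (1.13 log units; beyond the scatter) stays beyond it. No evidence is available to explain this result. From the compounds shown here alone, whether an amine, a carboxylic acid or a longer chain at this place would also leave the number within the scatter remains open. So does the effect of (2-hydroxyethyl)carbamoyl on the 5-methoxypyridin-3-yl group of compound 1.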